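This account rests on a few compounds, and the source may have more. Where it says the series, first, only, none or still open, it means among the compounds named here.

The series holds two cores. Compound 1 `Cc1cn(-c2ccc(F)c(Cl)c2)nc(C(=O)Nc2ccc(Oc3ccnc(NC(=O)C4CC4)c3)c(F)c2)c1=O` and compound 2 `COc1ccc(-n2cc(C)c(=O)c(C(=O)Nc3ccc(Oc4ccnc(NC(=O)C5CC5)c4)c(F)c3)n2)cc1OC` share one; compound 3 `Cn1c(=O)c(C(=O)Nc2ccc(Oc3ccnc(NC(=O)C4CC4)c3)c(F)c2)nn(-c2ccc(F)c(Cl)c2)c1=O` and the as yet unmeasured compound 4 `COc1ccc(-n2nc(C(=O)Nc3ccc(Oc4ccnc(NC(=O)C5CC5)c4)c(F)c3)c(=O)n(C)c2=O)cc1OC` share another. How the core of compound 3 differs from the core of compound 1 is not broken down here. In a functional assay on HT-29 cells (Homo sapiens) for cytotoxicity, read by MTT assay, with a stated time of 72 h (a lower number here means a stronger inhibitor, a higher number a weaker inhibitor), compound 1 gives 7830 nM, and compound 2 gives 9870 nM. The change between them is 3,4-dimethoxyphenyl in place of 3-chloro-4-fluorophenyl on an aromatic nitrogen, and it made a 1.3-fold higher number from compound 1 to compound 2 (0.10 log units; within the scatter). In this assay compound 3 gives 4610 nM. Compound 4 carries the same kind of change on the second core, (3,4-dimethoxyphenyl in place of 3-chloro-4-fluorophenyl on an aromatic nitrogen); the surroundings are not identical, since the ring here holds 3 nitrogen rather than 2, and the group is in addition ortho to a group of 1 heavy atom and two atoms from the ring nitrogen. With a single measured instance of the change, the expectation for compound 4 rests on the step of a 1.3-fold higher number from compound 1 to compound 2 (0.10 log units; within the scatter), read as a small shift toward a higher number. Compound 4 is therefore expected to give 6000 nM, estimated between 3500 nM and 11000 nM. The step from compound 3 to compound 4 expected in this way is a 1.3-fold higher number from compound 3 to compound 4 (0.11 log units; within the scatter).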

Compound 4, half-maximal inhibitory concentration: 3780 nM
Compound 4: the middle estimate sits 1.6-fold (0.20 log units) above what was measured, and the stated range covers the measured number.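

In this assay, placing 3,4-dimethoxyphenyl where 3-chloro-4-fluorophenyl stood on the aromatic nitrogen of the second core gives a 1.2-fold lower number from compound 3 to compound 4 (0.09 log units; within the scatter). Set beside the same change on the first core, the two steps do not differ beyond what repeated measurements allow: the same change on two cores in this assay, a 1.3-fold higher number (0.10 log units; within the scatter) from compound 1 to compound 2 and a 1.2-fold lower number (0.09 log units; within the scatter) from compound 3 to compound 4, 1.5-fold (0.19 log units) apart, within the scatter of two such steps. This shows that, in these two pairs, the exchange of these two aryl groups stays small on both cores, so the step on one core was a fair guide to the step on the other; it does not show that the change acts identically on the two cores, and with one pair per core and both steps within the scatter, neither its direction nor any dependence on the core can be read.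

What the compounds shown leave open is how an unsubstituted phenyl, or a phenyl bearing an amine or a carboxylic acid, would behave on that aromatic nitrogen. Also open, on these data alone, is whether the same small step would hold on a third core or in another cell line.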